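The compounds below may be only part of what the source reports. "The series", "measured", "known", "first", "only" and "open" are said of these compounds alone.

Working notes on the series. Compound 1 `Cc1cn([C@@H]2O[C@H](CO[Si](C)(C)C(C)(C)C)[C@@]3(OS(=O)(=O)C=C3NC(=O)NC(=O)c3ccccc3)[C@H]2O[Si](C)(C)C(C)(C)C)c(=O)n(C)c1=O` and compound 2 `Cc1cn([C@@H]2O[C@H](CO[Si](C)(C)C(C)(C)C)[C@@]3(OS(=O)(=O)C=C3NC(=O)NC(=O)c3ccccc3)[C@H]2O)c(=O)n(C)c1=O` have been measured in an ADME assay on HEL cells (Homo sapiens) for cytotoxicity, with a stated time of 3 days (on this read-out lower numbers stand for higher toxicity in this test and higher numbers for lower toxicity in this test), while compound 3 `Cc1cn([C@@H]2O[C@H](CO[Si](C)(C)C(C)(C)C)[C@@]3(OS(=O)(=O)C=C3NC(=O)NC(=O)c3ccccc3)[C@H]2O[Si](C)(C)C(C)(C)C(C)C)c(=O)n(C)c1=O` awaits measurement. In this assay compound 1 gives >= 80000 nM, which is a limit of the assay rather than a number. In this assay compound 2 gives > 100000 nM, again a limit. Among the compounds with values here, compound 2 thus stands at the edge of what the assay reports, as does the one other value shown. Within the data shown here, the only measured step, a step that the two limits leave unreadable from compound 1 to compound 2, ends at limits on both sides (the limit of > 100000 nM in this assay, at which 1 of the 2 values shown sits, (the limit of >= 80000 nM in this assay, at which 1 of the 2 values shown sits)), so no size can be read from it. Compound 3 differs from compound 2 by a group of 9 heavy atoms (8 carbon, 1 silicon; no ring) in place of a hydrogen atom, on an oxygen on a saturated carbon. Compound 1 already carries a group on an oxygen on a saturated carbon and sits at >= 80000 nM, a limit. The step of a number no higher from compound 2 to compound 3 (the limit leaves the size open) is therefore expected to be none beyond the scatter. Compound 3 is estimated at 100000 nM, within 50000 nM to 200000 nM, most likely reported as a limit.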

Compound 3, minimum cytotoxic concentration: >= 100000 nM
Compound 3 ended at the assay's limit (the forecaster's own chance of this, stated with the estimate: 85%); the middle value lies on the limit itself.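

In this assay, within the data shown here, compound 1, compound 2 and compound 3 all stand at limits of the assay, and no step among them can be read. The compounds shown leave open whether the group on the oxygen changes this read-out at all.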